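The source may report more compounds than this note shows. Statements on the series, on what has been measured and on what is new or still open speak of the compounds shown alone.

Measured so far in a functional assay on L1210 cells (Mus musculus) for cytotoxicity; a higher number here means a weaker inhibitor, a lower number a stronger inhibitor:
- compound 1 `O=C(/C=C/C(=O)N1C/C(=C\c2ccc([N+](=O)[O-])cc2)C(=O)/C(=C/c2ccc([N+](=O)[O-])cc2)C1)Nc1ccc(Cl)c(Cl)c1`: 1700 nM
- compound 2 `O=C(/C=C/C(=O)N1C/C(=C\c2ccc([N+](=O)[O-])cc2)C(=O)/C(=C/c2ccc([N+](=O)[O-])cc2)C1)Nc1ccc([N+](=O)[O-])cc1`: 1000 nM

Compound 2, at 1000 nM, lies within the scatter of compound 1, at 1700 nM. Only these two numbers are available, so the position of compound 2 within the series is only loosely defined.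

The next compound is compound 3 `Cc1ccc(NC(=O)/C=C/C(=O)N2C/C(=C\c3ccc([N+](=O)[O-])cc3)C(=O)/C(=C/c3ccc([N+](=O)[O-])cc3)C2)cc1C`. The change is 3,4-dimethylphenyl in place of 4-nitrophenyl on an amide-type nitrogen. In words, 3,4-dimethylphenyl takes the place of 4-nitrophenyl on an amide-type nitrogen, while the shared core stays the same.

Going by the values given here, one measured step bears on this change: a 1.7-fold lower number from compound 1 to compound 2 (0.23 log units; within the scatter). It is an exchange on the same nitrogen, 4-nitrophenyl in place of 3,4-dichlorophenyl, and it does not go beyond the scatter. Among the compounds with values here, no compound with a 3,4-dimethylphenyl group has a number yet, so this single step is weak guidance and the range is kept wide.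

In this assay, no step beyond the scatter is expected, and the working expectation is a 1.5-fold higher number from compound 2 to compound 3 (0.18 log units; within the scatter). For compound 3 the estimated value is 1500 nM, with an expected range of 600 nM to 4000 nM.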

Compound 3, half-maximal inhibitory concentration: 4900 nM
Beside the measured number, compound 3's estimate is 3.3-fold (0.51 log units) below it; measured number above the stated range.
By their numbers in this assay, from the lowest: compounds 2 and 1 (each within the scatter of the next); then compound 3.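

In this assay, the aryl group on the amide-type nitrogen now produces a step beyond the scatter: a 4.9-fold higher number from compound 2 to compound 3 (0.69 log units; beyond the scatter), and a 2.9-fold higher number from compound 1 to compound 3 (0.46 log units; beyond the scatter). Going by these compounds alone, the earlier exchange at this place, 4-nitrophenyl for 3,4-dichlorophenyl, stayed within the scatter, so it gave no sign that the group here matters; 3,4-dimethylphenyl is the first group to stand apart from the other two, and compound 3 is the weakest of the three, though both steps are modest. Nothing in hand gives a reason for this separation, so it stands as an observation on these three compounds only.

Three aryl groups on one nitrogen give no trend, and the data do not tell whether the step belongs to the pair of methyl groups together or to a single one of them. Unsubstituted phenyl, a methoxyphenyl or a carboxylic acid on the ring would test how far the series extends, and a cyclohexyl group or a longer alkyl chain would test whether an aromatic ring is needed at this place at all.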